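Diethylamino swap on the ketone aryl of compound 2

This account rests on a few compounds, and the source may have more. Where it says the series, first, only, none or still open, it means among the compounds named here.

Compound 2 `COc1ccc(/C=C/c2cc(OC)cc(OC)c2/C=C/C(=O)c2cccc(Cl)c2)cc1` gives 3.3 ug/mL in a functional assay on B16-F10 cells (Mus musculus) for antiproliferative activity, read by MTT assay, with a stated time of 48 h (on this read-out higher numbers stand for weaker inhibition and lower numbers for stronger inhibition), the lowest of the three numbers, yet within the scatter of compound 3 `COc1ccc(/C=C/c2cc(OC)cc(OC)c2/C=C/C(=O)c2ccccc2)cc1` at 3.7 ug/mL and of compound 1 `CCCCOc1ccc(C(=O)/C=C/c2c(/C=C/c3ccc(OC)cc3)cc(OC)cc2OC)cc1` at 5.3 ug/mL. Compound 4 `CCN(CC)c1ccc(C(=O)/C=C/c2c(/C=C/c3ccc(OC)cc3)cc(OC)cc2OC)cc1` differs from compound 2 in one place: 4-(diethylamino)phenyl in place of 3-chlorophenyl on a carbonyl carbon. Three earlier changes at or on that same aryl group all stayed within the scatter: a 1.6-fold lower number from compound 1 to compound 2 (0.21 log units; within the scatter), a 1.1-fold higher number from compound 2 to compound 3 (0.05 log units; within the scatter) and a 1.4-fold lower number from compound 1 to compound 3 (0.16 log units; within the scatter). Among the compounds with values here, no step shows a change beyond the scatter for any aryl group on the carbonyl carbon, so compound 4 is expected to show no step beyond the scatter, a 1.2-fold higher number from compound 2 to compound 4 (0.08 log units; within the scatter). Compound 4 is therefore estimated at 4 ug/mL, with a range from 1.5 ug/mL to 10 ug/mL.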

Compound 4, half-maximal inhibitory concentration: 8.1 ug/mL
Compound 4: the middle estimate sits 2.0-fold (0.31 log units) below what was measured; the range from low to high includes it.
By their numbers in this assay, from the lowest: compounds 2, 3, 1 and 4 (each within the scatter of the next, the first and the last beyond it).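

Unlike the earlier steps on the group at the carbonyl carbon, two steps here pass beyond the scatter, though only modestly: 4-(diethylamino)phenyl in place of 3-chlorophenyl gives a 2.5-fold higher number from compound 2 to compound 4 (0.39 log units; beyond the scatter) and diethylamino in place of hydrogen gives a 2.2-fold higher number from compound 3 to compound 4 (0.34 log units; beyond the scatter) on the same read-out. Diethylamino in place of butoxy gives a 1.5-fold higher number from compound 1 to compound 4 (0.18 log units; within the scatter) and so cannot be told apart from butoxy here. Nothing available accounts for these steps.

As far as these compounds go, whether a dimethylamino, a morpholine or a carboxylic acid on that aromatic carbon would match compound 4 remains open.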